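A few compounds are considered here, and "the series" means these few. Any claim that something is new, unique, unknown or untested is made for them only; others in the source may bear on it.

Three compounds share one core and differ only in the aromatic group attached to it. Compound 1 `Cn1nc(N)c2c(=O)[nH]c(-c3ccccc3)cc21` carries a phenyl; in an assay on isolated protein for inhibition of protein kinase C zeta type (Homo sapiens), read by mobility shift assay, tested at 30 uM (a higher number here means more inhibition at the concentration tested (going by the name of the read-out), a lower number less inhibition), compound 1 gives 6%. Compound 2 `Cn1nc(N)c2c(=O)[nH]c(-c3ccccn3)cc21` carries a pyridin-2-yl in its place and in this assay compound 2 gives 0%, while compound 3 `COc1ccc(-c2cc3c(c(N)nn3C)c(=O)[nH]2)cc1` bears an added methoxy and in this assay compound 3 gives -3%. The two steps, a number 6 percentage points lower from compound 1 to compound 2 (within the scatter) and a number 9 percentage points lower from compound 1 to compound 3 (within the scatter), are both within the scatter, so none of the three separates from the others; all sit near zero.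

Compound 4 `CC(=O)Nc1nn(C)c2cc(-c3ccccc3)[nH]c(=O)c12` is not yet measured. It differs from compound 1 by acetyl in place of hydrogen on a nitrogen on an aromatic ring. Within the data shown here, neither measured step touches this nitrogen; both alter the aromatic group, so no measured step bears directly on the change. Among the measured compounds shown here, the only guide is that every change tried so far has left this assay within the scatter. The step to compound 4 is therefore expected to stay within the scatter as well, with an estimated a number 3 percentage points lower from compound 1 to compound 4 (within the scatter). Compound 4 is expected to give 3% in this assay, within a range from -8% to 14%.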

Compound 4, a percentage reported as inhibition, at one concentration (the size of the read-out at that concentration, not a potency): 28%
Estimate against measurement, compound 4: 25 percentage points below, and the stated range ends below it.
By their numbers in this assay, from the lowest: compounds 3, 2 and 1 (each within the scatter of the next); then compound 4.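

Among these compounds, the amino group on the shared core is the first place where a change clearly moves the reading: in this assay, going from amino to acetamido gives a number 22 percentage points higher from compound 1 to compound 4 (beyond the scatter). The two changes to the aromatic group stayed within the scatter, so among these compounds this nitrogen is the only position shown to affect the reading, and it accepts an acetyl with a gain rather than a loss of inhibition. Nothing measured here explains this gain.

The compounds shown leave open whether the gain is specific to acetyl or would also appear with a longer chain such as butanoyl, with a benzoyl, or with a methyl on this nitrogen. They also leave open whether an acetamido would give a similar gain alongside the pyridin-2-yl of compound 2 or the added methoxy of compound 3.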